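The source may hold more compounds than are shown below. What is called first, only, known or untested is meant among the compounds shown, and "the series" means these compounds.

For the measured compounds named here, compound 2 `O=C1COc2ccc(-c3nn(-c4cc(Cl)cc(Cl)c4)cc3-c3ccccc3)cc2N1` gives 93.1% in a functional assay on A549 cells (Homo sapiens) for cytotoxicity, read by colorimetric assay and MTT assay, with a stated time of 3 days, tested at 1 uM (a higher number here means a weaker effect of the compound at the concentration tested, a lower number a stronger effect), the higher of the two numbers measured so far, while compound 1 `O=C1COc2ccc(-c3nn(-c4ccc(F)cc4)cc3-c3ccccc3)cc2N1` gives 78.2% in this assay. Going by the values given here, the only known step, a number 14.9 percentage points higher from compound 1 to compound 2 (beyond the scatter), came from replacing 4-fluorophenyl with 3,5-dichlorophenyl. Compound 3 `O=C1COc2ccc(-c3nn(-c4ccccc4)cc3-c3ccccc3)cc2N1` differs from compound 2 by phenyl in place of 3,5-dichlorophenyl on an aromatic nitrogen, so here the halogens are removed altogether and that step is only a loose guide. With a bare ring probably standing between the two measured cases, compound 3 is expected to give 82% in this assay, within 68% to 96%. This amounts to an expected step of a number 11.1 percentage points lower from compound 2 to compound 3 (beyond the scatter).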

Compound 3, a percentage reported as activity, at one concentration (the size of the read-out at that concentration, not a potency): 92.2%
Compound 3: the middle estimate sits 10.2 percentage points below what was measured, within the range that was stated.
By their numbers in this assay, from the lowest: compound 1; then compounds 3 and 2 (each within the scatter of the next).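

In this assay, the phenyl and 3,5-dichlorophenyl groups on the aromatic nitrogen cannot be told apart, with a number 0.9 percentage points lower from compound 2 to compound 3 (within the scatter), so the chlorines show no measurable effect here. By contrast, hydrogen in place of fluoro gives a number 14 percentage points higher from compound 1 to compound 3 (beyond the scatter), leaving compound 1 alone with the stronger effect among these three. Nothing available explains this difference. Still open, on these data alone, is whether the fluoro itself matters or whether another group on this phenyl ring, such as a methoxy or an amine, would also give a stronger effect.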